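Replacing naphthalen-1-yl with 3,4,5-trimethoxyphenyl in compound 1

A few compounds are considered here, and "the series" means these few. Any claim that something is new, unique, unknown or untested is made for them only; others in the source may bear on it.

In a functional assay on HCT-116 cells (Homo sapiens) for cytotoxicity, read by sulforhodamine B assay, with a stated time of 48 h (a lower number here means a stronger inhibitor, a higher number a weaker inhibitor), compound 1 (`COc1cc(/C=C/C(=O)/C=C/c2cccc3ccccc23)ccc1OCc1cn(CCCOc2cc(=O)oc3ccccc23)nn1`) gives 10400 nM as the highest of three measured numbers. Compound 2 (`COc1cc(/C=C/C(=O)/C=C/c2cccs2)ccc1OCc1cn(CCOc2cc(=O)oc3ccccc23)nn1`) gives 9290 nM and lies within the scatter of compound 1. Compound 3 (`COc1ccc(/C=C/C(=O)/C=C/c2ccc(OCc3cn(CCOc4cc(=O)oc5ccccc45)nn3)c(OC)c2)cc1OC`) gives 4710 nM and lies lower than compound 1, beyond the scatter.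

Compound 4 (`COc1cc(/C=C/C(=O)/C=C/c2cc(OC)c(OC)c(OC)c2)ccc1OCc1cn(CCCOc2cc(=O)oc3ccccc23)nn1`) has yet to be measured in this assay and carries 3,4,5-trimethoxyphenyl in place of naphthalen-1-yl on a double-bonded chain carbon bound to a double-bonded chain carbon.

Within the data shown here, only one measured step changes the group at that place. It is a 2.0-fold lower number from compound 2 to compound 3 (0.29 log units; within the scatter) with 3,4-dimethoxyphenyl in place of thiophen-2-yl, and it stays within the scatter. Compounds 2 and 3 also differ from compound 1 elsewhere in the structure, so this step is only a loose guide. Compound 3, with 3,4-dimethoxyphenyl at that place, gives 4710 nM and this value suggests a modest drop at most. The expected step is a 1.7-fold lower number from compound 1 to compound 4 (0.24 log units; within the scatter) and would stay within the scatter. For compound 4 the estimate is 6000 nM with an expected range of 2500 nM to 14000 nM around it.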

Compound 4, half-maximal inhibitory concentration: 8650 nM
Compound 4: middle estimate off by 1.4-fold (0.16 log units), on the low side; low and high end bracket the measured number.
By their numbers in this assay, from the lowest: compounds 3, 4, 2 and 1 (each within the scatter of the next, the first and the last beyond it).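

In this assay, the change gives a 1.2-fold lower number from compound 1 to compound 4 (0.08 log units; within the scatter), so compound 1 and compound 4 cannot be told apart, although they differ only at this place. The exchange replaces two six-membered aromatic rings of carbon only with one such ring, and a group with no hydrogen-bond acceptors with one that has 3, yet this large change in the group leaves the number within the scatter, which the earlier step at this place, with its other differences in the structure, could not show directly. Nothing available here accounts for this outcome.

The compounds shown leave open whether a group of another kind at this place, such as an amine or a carboxylic acid, would move the number beyond the scatter. They also leave open whether 3,4,5-trimethoxyphenyl and naphthalen-1-yl would again give numbers within the scatter of each other if the chain joining the shared core to the triazole were longer.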